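The compounds below may be only part of what the source reports. "The series", "measured", "known", "first", "only" and "open" are said of these compounds alone.

Measured compounds in an ADME assay on Vero cells (Chlorocebus sabaeus) for cytotoxicity, read by MTT assay, with a stated time of 48 h; on this read-out higher numbers stand for weaker inhibition and lower numbers for stronger inhibition:
- compound 1, `CS(=O)(=O)NC1CCC(CN2CCN(c3cc(=O)c4cc(C(F)(F)F)cc([N+](=O)[O-])c4s3)CC2)CC1`, gives 48.5 ug/mL.
- compound 2, `CC(=O)NC1CCC(CN2CCN(c3cc(=O)c4cc(C(F)(F)F)cc([N+](=O)[O-])c4s3)CC2)CC1`, gives only the limit > 64 ug/mL; this is a limit of the assay, not a number.
- compound 3, `COc1ccc(C(=O)OC2CCC(CN3CCN(c4cc(=O)c5cc(C(F)(F)F)cc([N+](=O)[O-])c5s4)CC3)CC2)cc1`, gives only the limit > 64 ug/mL; this too is a limit, not a number.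

Compound 3 thus stands at the ceiling of this assay, and (the limit of > 64 ug/mL in this assay, at which 2 of the 3 values shown sit). The steps of an at least 1.3-fold higher number from compound 1 to compound 2 (0.12 log units; that floor lies within the scatter) and an at least 1.3-fold higher number from compound 1 to compound 3 (0.12 log units; that floor lies within the scatter) have floors that lie within the scatter, and the step that the two limits leave unreadable from compound 2 to compound 3 is unreadable, so none of the three compounds is separated from the others beyond the scatter.

Compound 4, `O=c1cc(N2CCN(CC3CCC(OS(=O)(=O)c4ccc5c(c4)CCO5)CC3)CC2)sc2c([N+](=O)[O-])cc(C(F)(F)F)cc12`, differs from compound 3 by a group of 12 heavy atoms (8 carbon, 3 oxygen, 1 sulfur; one five-membered non-aromatic ring with 1 hetero atom, one six-membered aromatic ring of carbon only) in place of a group of 10 heavy atoms (8 carbon, 2 oxygen; one six-membered aromatic ring of carbon only), on an oxygen on a saturated carbon. The two measured steps that end at this position, an at least 1.3-fold higher number from compound 1 to compound 3 (0.12 log units; that floor lies within the scatter) and a step that the two limits leave unreadable from compound 2 to compound 3, give no readable size, so no direction can be drawn from them for the change at hand. Compound 4 is expected to show a step of a number no higher from compound 3 to compound 4 (the limit leaves the size open) that stays within the scatter. The expected value for compound 4 is 64 ug/mL, with a range from 32 ug/mL to 128 ug/mL, most likely reported again as a limit.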

Compound 4, half-maximal inhibitory concentration: > 64 ug/mL
Compound 4 was reported as a limit; the forecaster's own chance of this, stated with the estimate: 70%; the middle value lies on the limit itself.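

In this assay compound 4 gives > 64 ug/mL, a limit and not a number. No new step can be read, as compound 3 and compound 4 both sit at a limit: the limit of > 64 ug/mL in this assay, at which 3 of the 4 values shown sit.

The compounds shown leave open how compound 2, compound 3 and compound 4 rank against one another.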